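Extending the Amide Methyl to Propargyl on the Glutamate Chain

The compounds below may be only part of what the source reports. "The series", "measured", "known", "first", "only" and "open" are said of these compounds alone.

Compound 2 `C#CCN(Cc1cc2c(O)nc(C)nc2cc1C)c1ccc(C(=O)N[C@@H](CCC(=O)O)C(=O)N(C)[C@@H](CCC(=O)O)C(=O)O)c(F)c1` gives the lowest of the three numbers in a functional assay for inhibition, with Mus musculus as the target (a lower number here means a stronger inhibitor, a higher number a weaker inhibitor), at 4000 nM. Compound 1 `C#CCN(Cc1ccc2nc(C)nc(O)c2c1)c1ccc(C(=O)N[C@@H](CCC(=O)O)C(=O)N[C@@H](CCC(=O)O)C(=O)O)cc1` stands nearest to it in this assay with 4600 nM, a gap within the scatter, while compound 3 `C#CCN(Cc1ccc2nc(C)nc(O)c2c1)c1ccc(C(=O)N[C@@H](CCC(=O)O)C(=O)NC(C)(C)C(=O)O)cc1` lies furthest with 70000 nM. Going by the values given here, the single measured step, a 15-fold higher number from compound 1 to compound 3 (1.18 log units; beyond the scatter), concerns a different part of the molecule and does not touch the change now considered. Compound 4 `C#CCN(Cc1cc2c(O)nc(C)nc2cc1C)c1ccc(C(=O)N[C@@H](CCC(=O)O)C(=O)N(CC#C)[C@@H](CCC(=O)O)C(=O)O)c(F)c1` differs from compound 2 by ethynyl in place of hydrogen on a saturated chain carbon bound to an amide-type nitrogen; cut one bond further out, the change reads methyl to propargyl. Among the compounds with values here, no measured step bears on this position, so the analyst expects for compound 4 no step beyond the scatter, a 1.3-fold higher number from compound 2 to compound 4 (0.10 log units; within the scatter). The estimate for compound 4 in this assay is 5000 nM, with a range from 2000 nM to 13000 nM.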

Compound 4, half-maximal inhibitory concentration: 4200 nM
For compound 4 the middle estimate is 1.2-fold (0.08 log units) above the measured one, within the range that was stated.
By their numbers in this assay, from the lowest: compounds 2, 4 and 1 (each within the scatter of the next); then compound 3.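

In this assay, going by these compounds alone, the step of a 1.1-fold higher number from compound 2 to compound 4 (0.02 log units; within the scatter) gives the first reading at this position, which none of the earlier steps touched. Methyl and propargyl on the amide-type nitrogen cannot be told apart here, so ethynyl in place of hydrogen on this saturated chain carbon brings no step beyond the scatter. No available evidence offers an explanation for this result. The compounds shown leave open whether a longer chain, an amine or a carboxylic acid on this nitrogen would also stay within the scatter of compound 2.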